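Amino to Methoxy on the Aryl Ketone of Compound 1

The compounds below may be only part of what the source reports. "The series", "measured", "known", "first", "only" and "open" are said of these compounds alone.

Compound 1 `COc1cc(-c2cc(/C=C/C(=O)c3ccc(N)cc3)[nH]n2)cc(OC)c1OC`: -61%
Compound 2 `COc1ccc(-c2cc(/C=C/C(=O)c3ccc(OC)c(OC)c3)[nH]n2)cc1`: -58%
Compound 3 `COc1ccc(-c2cc(/C=C/C(=O)c3ccc(N)cc3)[nH]n2)cc1OC`: -82%

In a functional assay on ACHN cells (Homo sapiens) for cytotoxicity, read by sulforhodamine B assay, with a stated time of 48 h, tested at 10 uM (a lower number here means a stronger effect, a higher number a weaker effect of the compound at the concentration tested), compound 1 gives -61%, the second highest of the three numbers. Compound 2 lies nearest, and the gap between compound 2 and compound 1 is within the scatter. Compound 3 lies furthest, and the step of a number 21 percentage points lower from compound 1 to compound 3 (beyond the scatter) was a modest one, beyond the scatter, brought about by hydrogen in place of methoxy on an aromatic carbon.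

Compound 4 `COc1ccc(C(=O)/C=C/c2cc(-c3cc(OC)c(OC)c(OC)c3)n[nH]2)cc1` differs from compound 1 by methoxy in place of amino on an aromatic carbon, sitting on an aromatic carbon of a six-membered aromatic ring of carbon only, para to a large group. Within the data shown here, no measured step covers this exchange of amino for methoxy; the single measured step concerns the other aromatic ring and says nothing directly about the ketone-bearing ring. What the numbers do show is that compound 2, which carries methoxy groups rather than amino on its ketone-bearing ring, gives -58% in this assay, close to compound 1. Compound 4 is therefore expected to give -58%, within -80% to -35%. The expected step of a number 3 percentage points higher from compound 1 to compound 4 (within the scatter) is estimated to stay within the scatter.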

Compound 4, a percentage reported as activity, at one concentration (the size of the read-out at that concentration, not a potency): -83%
Estimate against measurement, compound 4: 25 percentage points above; measured number below the stated range.
By their numbers in this assay, from the lowest: compounds 4 and 3 (each within the scatter of the next); then compounds 1 and 2 (each within the scatter of the next).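

In this assay, the position on the six-membered aromatic ring of carbon only, para to a large group, proves sensitive to the group it carries: with methoxy in place of amino, there is a number 22 percentage points lower from compound 1 to compound 4 (beyond the scatter). Among these compounds, until now the only step between compounds differing in one place lay elsewhere in the molecule, a number 21 percentage points lower from compound 1 to compound 3 (beyond the scatter), so this is the first direct reading at this position, and it shows that amino is not required there for a number at the level of compound 4, -83%. It also shows that compound 2, which differs from compound 1 in more than one place, could not stand in for this single exchange, and no measurement available here explains the step.

Going by these compounds, whether the same change would move the number in the same direction in compound 3, which carries a different pattern of methoxy groups on the other ring, remains open. So does the response of this position to other groups, such as hydroxy, dimethylamino, a fluorine atom or a longer ether chain like ethoxy.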